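Cyano in place of trifluoromethyl in compound 2

The compounds below may be only part of what the source reports. "The series", "measured", "known", "first", "only" and "open" are said of these compounds alone.

Within the data shown here, in a functional assay on U-937 cells (Homo sapiens) for antiproliferative activity, with a stated time of 48 h (on this read-out lower numbers stand for an effect already at smaller amounts and higher numbers for an effect only at larger amounts of compound), three compounds sharing one core have numbers so far. Compound 1 (`O=C(CCCCCCC(=O)Nc1cccc(C(F)(F)F)c1)NO`) gives 1200 nM here and compound 3 (`O=C(CCCCCCC(=O)Nc1ccccc1Br)NO`) gives 6800 nM here. Compound 2 (`O=C(CCCCCCC(=O)Nc1ccc(C(F)(F)F)cc1)NO`) gives 450 nM as the lowest number of the three, clearly apart from both others. Compound 4 (`N#Cc1ccc(NC(=O)CCCCCCC(=O)NO)cc1`) is still unmeasured. It differs from compound 2 by cyano in place of trifluoromethyl on an aromatic carbon, para to a large group (cyano in place of trifluoromethyl on an aromatic carbon). Among the measured compounds shown here, no measured pair shows this change, so the expectation is loose. In this assay no step beyond the scatter is expected, with a slight lean toward a higher number. The expected change is a 1.6-fold higher number from compound 2 to compound 4 (0.19 log units; within the scatter) by this estimate. Compound 4 is expected near 700 nM within an estimated range (230 nM to 2100 nM).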

Compound 4, half-maximal effective concentration: 7000 nM
Estimate against measurement, compound 4: 10-fold (1.00 log units) below, outside the stated range (above it).
By their numbers in this assay, from the lowest: compound 2; then compound 1; then compounds 3 and 4 (each within the scatter of the next).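

In this assay, putting cyano in place of trifluoromethyl on this aromatic carbon is far from a neutral exchange (a 16-fold higher number from compound 2 to compound 4 (1.19 log units; beyond the scatter)). Among these compounds, this is the first step between compounds differing in one place, and it shows that the low number of compound 2 depends strongly on the group held here. Nothing measured here explains why the step is so large.

As far as these compounds go, whether a chlorine atom, a methoxy group or an amine on this same carbon would stay near compound 2 or land near compound 4 remains open.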